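The source may hold more compounds than are shown below. What is called first, only, known or untested is meant among the compounds shown, and "the series" means these compounds.

Compound 1 `Clc1cncc(Cl)c1N/N=C/c1ccccc1-c1c(Cl)cccc1Cl` belongs to a small set of three measured compounds, alongside compound 2 `Cc1ccccc1-c1ccc(N2CCN(C)CC2)nc1N(C)C(=O)C(C)(C)c1cc(C(F)(F)F)cc(C(F)(F)F)c1` and compound 3 `Cc1ccccc1-c1cnccc1N(C)C(=O)C(C)(C)c1cc(C(F)(F)F)cc(C(F)(F)F)c1`. In an assay on CHO cells for displacement of a labelled ligand from Substance-P receptor (Homo sapiens) (a higher number here means a weaker inhibitor, a lower number a stronger inhibitor), compound 1 gives 93 nM, the highest of the three numbers, which makes it the weakest inhibitor of the set. In this assay compound 3 gives 3.3 nM, and compound 2 gives 2 nM, each far lower than compound 1, beyond the usual scatter.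

Compound 4 `Cc1ccccc1-c1ccccc1/C=N/Nc1c(Cl)cncc1Cl` differs from compound 1 in one place: 2-methylphenyl in place of 2,6-dichlorophenyl on an aromatic carbon. For the measured compounds named here, compounds 2 and 3 carry the same 2-methylphenyl, but on a different core, so no measured step tells how this change behaves here. A step in this assay no larger than the scatter is expected, a 1.4-fold higher number from compound 1 to compound 4 (0.15 log units; within the scatter). Compound 4 is expected to give 130 nM, between 35 nM and 500 nM.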

Compound 4, inhibition constant: 316 nM
Beside the measured number, compound 4's estimate is 2.4-fold (0.39 log units) below it; measured number inside the range.
By their numbers in this assay, from the lowest: compounds 2 and 3 (each within the scatter of the next); then compound 1; then compound 4.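

In this assay, putting 2-methylphenyl in place of 2,6-dichlorophenyl gives a 3.4-fold higher number from compound 1 to compound 4 (0.53 log units; beyond the scatter). For the compounds shown here, this is the first measured step at this aromatic carbon, ortho to a large group, and it shows that the change is not silent here: within this pair, the 2,6-dichlorophenyl compound is the stronger inhibitor, though the step is modest. Nothing available here accounts for the shift. Still open, going by these compounds, is how a 2-chlorophenyl group or an unsubstituted phenyl ring would compare with these two groups at this position.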